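Halogen to trifluoromethyl on the fused ring: compound 2 to compound 3

A few compounds are considered here, and "the series" means these few. Any claim that something is new, unique, unknown or untested is made for them only; others in the source may bear on it.

Measured so far in a functional assay on the whole organism for inhibition, with Mus musculus as the target, at a dose of 1 mg/kg by the oral route; on this read-out higher numbers stand for more inhibition at the one dose given (going by the name of the read-out) and lower numbers for less inhibition:
compound 1, `CCN(C(=O)c1c(O)c2c(F)cccc2n(C)c1=O)c1ccccc1`, 60%
compound 2, `CCN(C(=O)c1c(O)c2c(Br)cccc2n(C)c1=O)c1ccccc1`, 95%

Compound 2 stands highest of the two numbers in this assay; its nearest neighbour is compound 1. For the measured compounds named here, the only measured step, a number 35 percentage points higher from compound 1 to compound 2 (beyond the scatter), comes from bromo in place of fluoro on an aromatic carbon, and it lies beyond the scatter.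

Compound 3, `CCN(C(=O)c1c(O)c2c(C(F)(F)F)cccc2n(C)c1=O)c1ccccc1`, differs from compound 2 by trifluoromethyl in place of bromo on an aromatic carbon. Going by the values given here, no measured pair swaps bromo for trifluoromethyl, so the one recorded step bears only indirectly: it shows that the group at this aromatic carbon moves this assay strongly, with the larger halogen giving the higher number. Trifluoromethyl is not a halogen, and its direction is unknown from these data.

Compound 3 is therefore expected to give 80% in this assay, with a range of 55% to 98%. The expected step is a number 15 percentage points lower from compound 2 to compound 3 (beyond the scatter), a modest drop that may fall within the scatter.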

Compound 3, a percentage reported as inhibition, in the whole organism at one dose (the size of the read-out at that dose, not a potency): 80%
For compound 3 middle estimate and measured number coincide at the digits printed; the measured number falls inside the stated range.
By their numbers in this assay, from the lowest: compound 1; then compound 3; then compound 2.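

In this assay the step of a number 15 percentage points lower from compound 2 to compound 3 (beyond the scatter) goes with trifluoromethyl in place of bromo and the step of a number 20 percentage points higher from compound 1 to compound 3 (beyond the scatter) goes with trifluoromethyl in place of fluoro, so a group that is not a halogen lands between the two halogens at this aromatic carbon. The order bromo, trifluoromethyl, fluoro does not follow the count of heavy atoms, and compound 3 is the one that goes against such a trend, since trifluoromethyl carries more heavy atoms than bromo yet reads lower. Nothing available bears on the reason for this order.

Still open, from the compounds shown here alone, is how an amine or a nitrile at this aromatic carbon would read. Also open, going by these compounds, is whether the same order of the three groups holds when the shared core changes elsewhere, for instance at the ethyl group on the amide nitrogen.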